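The source may report more compounds than this note shows. Statements on the series, on what has been measured and on what is new or still open speak of the compounds shown alone.

In an assay on RPMI-8226 cells for antagonist activity at P2X purinoceptor 7 (Homo sapiens), read by calcium flux (a lower number here means a stronger inhibitor, a higher number a weaker inhibitor), three compounds built around a diphenylmethyl group and a basic ring amine have been measured. Compound 1 `O=C(C(c1ccccc1)c1ccccc1)N1CCN(CCCn2c(=O)[nH]c3ccccc32)CC1` gives 7800 nM, compound 2 `O=c1[nH]c2ccccc2n1CCCN1CCC(=C(c2ccccc2)c2ccccc2)CC1` gives 2400 nM, and compound 3 `O=c1[nH]c2ccccc2n1CCCCN1CCN(C(c2ccccc2)c2ccccc2)CC1` gives 180 nM. Compound 3 thus stands at the lowest number of the three, with compound 2 and compound 1 both beyond the scatter above it, so compound 3 is the strongest inhibitor of the set.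

Compound 4 `Cc1cccc2ccn(CCCCN3CCN(C(c4ccccc4)c4ccccc4)CC3)c12` has not been measured. It differs from compound 3 in one place: a group of 10 heavy atoms (9 carbon, 1 nitrogen; one five-membered aromatic ring with 1 hetero atom, one six-membered aromatic ring of carbon only) in place of a group of 10 heavy atoms (7 carbon, 2 nitrogen, 1 oxygen; one five-membered aromatic ring with 2 hetero atoms, one six-membered aromatic ring of carbon only), on a saturated chain carbon, four bonds along the chain from an amine nitrogen in a ring. The group that enters has no hydrogen-bond donor and one acceptor fewer than the group that leaves, and the four-carbon chain and the rest of the molecule are unchanged.

Going by the values given here, no step of this kind is known among the measured compounds, so the expectation rests on compound 3 alone. Because compound 3 gives 180 nM, compound 4 is expected to remain a recognisable inhibitor in this assay, but the loss of the donor and of one acceptor is judged more likely to weaken than to strengthen it, so a step of modest size toward a higher number is expected, a 3.3-fold higher number from compound 3 to compound 4 (0.52 log units; beyond the scatter). Compound 4 is therefore estimated at 600 nM, within a range from 150 nM to 3000 nM.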

Compound 4, half-maximal inhibitory concentration: 2300 nM
Beside the measured number, compound 4's estimate is 3.8-fold (0.58 log units) below it; the range from low to high includes it.
By their numbers in this assay, from the lowest: compound 3; then compounds 4 and 2 (each within the scatter of the next); then compound 1.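

In this assay, putting 7-methyl-1H-indol-1-yl in place of the earlier group gives a 13-fold higher number from compound 3 to compound 4 (1.11 log units; beyond the scatter), a large step beyond the scatter. Going by these compounds alone, it shows that the number depends strongly on what sits on this saturated chain carbon, four bonds along the chain from an amine nitrogen in a ring, which the earlier compounds could not show, as no two of them formed a one-place step. The two groups match in heavy atoms and in their aromatic ring types, so the step comes with a change in the group's atoms and the loss of its hydrogen-bond donor rather than with a change in heavy-atom count, though nothing measured here bears on its cause.

The compounds shown leave open whether the methyl group contributes to the step, and an unsubstituted indol-1-yl group would address that, while an indol-1-yl group carrying a hydroxyl group would test whether a hydrogen-bond donor returns the number towards that of compound 3, which gives 180 nM. Also open, from the compounds shown here alone, is how a five-carbon chain in place of the four-carbon chain would read with either group.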